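The source may report more compounds than this note shows. Statements on the series, on what has been measured and on what is new or still open speak of the compounds shown alone.

Compound 1 `CCNC1=NS(=O)(=O)c2ccc(Cl)cc2N1`: 54800 nM
Compound 2 `O=S1(=O)N=C(NC2CC2)Nc2cc(Cl)ccc21`: 156000 nM

In a functional assay on aorta (Rattus norvegicus) for inhibition (a lower number here means that less compound is needed, a higher number that more compound is needed for the effect), compound 2 has the higher of the two numbers, at 156000 nM. Compound 3 `O=S1(=O)N=C(NC2CCC2)Nc2cc(Cl)ccc21` keeps the shared core and makes one change: cyclobutyl in place of cyclopropyl on an amine nitrogen. Going by the values given here, only one measured step bears on this, a 2.8-fold higher number from compound 1 to compound 2 (0.45 log units; beyond the scatter), a modest one that brought in cyclopropyl in place of ethyl. It is a different swap at that nitrogen, so it offers only a loose guide, and no step beyond the scatter is expected in this assay. The estimated step is a 1.4-fold lower number from compound 2 to compound 3 (0.15 log units; within the scatter). For compound 3 the expected value is 110000 nM, with an estimated range of 40000 nM to 300000 nM.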

Compound 3, half-maximal effective concentration: > 300000 nM
Compound 3: only a limit was reported; the forecaster's own chance of this, stated with the estimate: 15%; at least 2.7-fold (0.43 log units) between middle value and limit.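

Compound 3 gives only a limit of the assay, not a number: the limit of > 300000 nM in this assay, at which 1 of the 3 values shown sits. Against cyclopropyl, the cyclobutyl ring gives an at least 1.9-fold higher number from compound 2 to compound 3 (0.28 log units; that floor lies within the scatter), so this swap alone is not shown to shift the result. Against ethyl, it gives an at least 5.4-fold higher number from compound 1 to compound 3 (0.73 log units; beyond the scatter), so the larger gap at this amine nitrogen appears only when compound 3 is set against the ethyl compound.

On these data alone, how far the true value of compound 3 lies past its limit remains open. So does whether methyl, a longer chain or a cyclopentyl ring on this nitrogen would lower the number.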